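The source may hold more compounds than are shown below. What is called first, only, known or untested is meant among the compounds shown, and "the series" means these compounds.

Measured in a functional assay on PC-3 cells (Homo sapiens) for cytotoxicity, read by WST assay, with a stated time of 48 h; a lower number here means a stronger inhibitor, a higher number a weaker inhibitor:

Compound 1 `N#C/C(=C\c1c[nH]c2ccccc12)C(=O)c1c[nH]c2ccccc12`: > 50000 nM
Compound 2 `N#C/C(=C\c1cn(Cc2ccc(Cl)cc2)c2ccccc12)C(=O)c1c[nH]c2ccccc12`: > 50000 nM
Compound 3 `COc1ccc(Cn2cc(/C=C(\C#N)C(=O)c3c[nH]c4cc(F)ccc34)c3ccccc32)cc1`: > 50000 nM

Each of these entries is a limit of the assay and not a number. In this assay compound 3 gives > 50000 nM, which is such a limit, so it cannot be ranked against the other two. All the results so far sit at one mark: the limit of > 50000 nM in this assay, at which 3 of the 3 values shown sit.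

Compound 4 `COc1ccc(Cn2cc(/C=C(\C#N)C(=O)c3c[nH]c4ccccc34)c3ccccc32)cc1` differs from compound 3 in one place: hydrogen in place of fluoro on an aromatic carbon. In words, hydrogen stands in place of fluoro on an aromatic carbon, turning 6-fluoro-1H-indol-3-yl into 1H-indol-3-yl.

Going by the values given here, only one measured step exists: a step that the two limits leave unreadable from compound 1 to compound 2. It places 4-chlorobenzyl on an aromatic nitrogen, not on the aromatic carbon that changes here, and its size cannot be read. Among the compounds with values here, no measured step removes a fluoro, so no size can be carried over.

The expectation therefore rests on compound 3, whose > 50000 nM is a limit. No step beyond the scatter is expected in this assay, and the assay will most likely report only a limit again. The expected step, a number no higher from compound 3 to compound 4 (the limit leaves the size open), is an estimate with no clear direction. For compound 4 the estimated value is 50000 nM, with an expected range from 15000 nM to 100000 nM.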

Compound 4, half-maximal inhibitory concentration: > 50000 nM
Compound 4: a limit, no number; the forecaster's own chance of this, stated with the estimate: 70%; the middle value lies on the limit itself.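

In this assay compound 4 gives > 50000 nM, which is a limit of the assay and not a number. Its steps from compound 1, compound 2 and compound 3 therefore cannot be read, and all results now share one mark: the limit of > 50000 nM in this assay, at which 4 of the 4 values shown sit.

The compounds shown leave open how strongly any of them acts on these cells, and whether a fluoro, 4-chlorobenzyl or 4-methoxybenzyl group changes that at all.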